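The compounds below may be only part of what the source reports. "The series", "measured", "known", "first", "only" and "open" are said of these compounds alone.

Compounds measured so far:
compound 1 `Cc1nc(N2CCC(C(=O)NC(C)C)CC2)nc2ccc(NC(=O)COc3ccc(Cl)cc3)cc12` — 25 nM
compound 2 `Cc1nc(N2CCC(C)(O)CC2)nc2ccc(NC(=O)COc3ccc(Cl)cc3)cc12` — 827 nM

In a functional assay on CHO-K1 cells for antagonist activity at melanin-concentrating hormone receptor 1 (Homo sapiens), read by inositol phosphate accumulation (a higher number here means a weaker inhibitor, a lower number a stronger inhibitor), compound 1 gives 25 nM and compound 2 gives 827 nM; compound 2 thus stands at the higher of the two numbers, the weaker inhibitor of the pair, and its gap to compound 1 lies well beyond the usual scatter. Compound 3 `Cc1nc(N2CCN(CC(C)(C)C)CC2)nc2ccc(NC(=O)COc3ccc(Cl)cc3)cc12` has not been measured yet. It differs from compound 2 in one place: 4-neopentylpiperazin-1-yl in place of 4-hydroxy-4-methylpiperidin-1-yl on an aromatic carbon. Among the compounds with values here, the two measured compounds show that what sits on this aromatic carbon can move the number a long way, but no measured step isolates the exchange made here, so the direction must be judged from compound 2 alone. A drop in the number is expected for compound 3, with the step from compound 2 to compound 3 estimated at an 8.3-fold lower number from compound 2 to compound 3 (0.92 log units; beyond the scatter). For compound 3 the estimate in this assay is 100 nM, expected between 20 nM and 500 nM.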

Compound 3, half-maximal inhibitory concentration: 246 nM
Estimate against measurement, compound 3: 2.5-fold (0.39 log units) below; measured number inside the range.
By their numbers in this assay, from the lowest: compound 1; then compound 3; then compound 2.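

In this assay, the exchange gives a 3.4-fold lower number from compound 2 to compound 3 (0.53 log units; beyond the scatter), so this aromatic carbon accepts a larger group that has no hydrogen-bond donor and a second ring nitrogen, and the number still falls. The hydrogen-bond donor of 4-hydroxy-4-methylpiperidin-1-yl is therefore not required for a number of this size, although compound 1, at 25 nM, still has the lowest number of the three. No measurement available here explains why the number falls.

Because the hydroxyl, the ring atom and the neopentyl chain all change in this one step, their separate contributions cannot be told apart. A 4-methylpiperazin-1-yl group, or a piperidine carrying a neopentyl chain at its 4-carbon, would help to show whether the second ring nitrogen or the bulky chain matters more.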